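The source may hold more compounds than are shown below. What is called first, only, known or untested is meant among the compounds shown, and "the series" means these compounds.

Measured compounds:
Compound 1 `CCCCOC(=O)CCC(=O)N1CCN(CCCOc2cc3c(Nc4ccc(F)c(Cl)c4)ncnc3cc2OC)CC1` — in a functional assay on A549 cells (Homo sapiens) for cytotoxicity, read by MTT assay, with a stated time of 24 h, tested at 80 uM (on this read-out lower numbers stand for a stronger effect and higher numbers for a weaker effect at the one concentration tested), compound 1 gives 36.9%.
Compound 2 `CCCCCCCOC(=O)CCC(=O)N1CCN(CCCOc2cc3c(Nc4ccc(F)c(Cl)c4)ncnc3cc2OC)CC1` — in this assay compound 2 gives 27.2%.

Compound 2 stands at the lowest of the two numbers; its nearest neighbour is compound 1, and the step of a number 9.7 percentage points lower from compound 1 to compound 2 (within the scatter) lies within the scatter. Compound 3 `CCCCCCCCOC(=O)CCC(=O)N1CCN(CCCOc2cc3c(Nc4ccc(F)c(Cl)c4)ncnc3cc2OC)CC1` is the next member. The change from compound 2 to compound 3 is methyl in place of hydrogen on a saturated chain carbon, seven bonds along the chain from an oxygen next to a carbonyl group. Among the measured compounds shown here, the only measured step that bears on this change is the longer one from compound 1 to compound 2, where propyl in place of hydrogen on a saturated chain carbon gave a step within the scatter. A single methyl added one bond further out is therefore expected to give at most a small downward step, a number 3.2 percentage points lower from compound 2 to compound 3 (within the scatter), not beyond the scatter. Compound 3 is estimated at 24%, with a likely range from 12% to 37%.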

Compound 3, a percentage reported as activity, at one concentration (the size of the read-out at that concentration, not a potency): 21.7%
For compound 3 the middle estimate is 2.3 percentage points above the measured one; measured number inside the range.
By their numbers in this assay, from the lowest: compounds 3, 2 and 1 (each within the scatter of the next, the first and the last beyond it).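

In this assay, methyl in place of hydrogen on a saturated chain carbon, seven bonds along the chain from an oxygen next to a carbonyl group, gives a number 5.5 percentage points lower from compound 2 to compound 3 (within the scatter), so this one change does not separate the two compounds. Among the compounds shown here, the two changes along the chain taken together give a number 15.2 percentage points lower from compound 1 to compound 3 (beyond the scatter), the first step in this chain to pass beyond the scatter, which shows a modest effect only across the whole extension. Nothing measured here accounts for that step.

From the compounds shown here alone, whether a longer chain than that of compound 3 would go further in the same direction remains open, as does whether an amine or a carboxylic acid in place of the added methyl would keep the effect.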